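A few compounds are considered here, and "the series" means these few. Any claim that something is new, unique, unknown or untested is made for them only; others in the source may bear on it.

Of the compounds shown here, two have so far been measured in a functional assay on HepG2 cells (Homo sapiens) for inhibition, read by fluorescence and resazurin assay, with a stated time of 72 h; on this read-out lower numbers stand for stronger inhibition and higher numbers for weaker inhibition. Compound 1 `O=C(Nc1ccccc1)Nc1ccc(Nc2nccc(Nc3ccc4cn[nH]c4c3)n2)cc1` gives 11000 nM, and compound 2 `Cc1cnc(Nc2cccc(NC(=O)Nc3ccccc3)c2)nc1Nc1ccc2cn[nH]c2c1` gives 3600 nM. Compound 2 therefore holds the lower of the two numbers, meaning the stronger inhibition of the pair, and the gap between them lies beyond the usual scatter of repeated measurements.

The next compound, compound 3 `Nc1cnc(Nc2cccc(NC(=O)Nc3ccccc3)c2)nc1Nc1ccc2cn[nH]c2c1`, is still unmeasured in this assay. It keeps compound 2 intact except for one change: amino in place of methyl on an aromatic carbon. This is amino in place of methyl on an aromatic carbon, ortho to a (1H-indazol-6-yl)amino group and para to a large group.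

Among the compounds with values here, no measured pair here shows what a single change does in this assay, so the data offer no direct guide to its size or direction. The expectation therefore rests only on how small the swap is, and it is for no shift beyond the scatter. The estimated step of a 1.1-fold higher number from compound 2 to compound 3 (0.05 log units; within the scatter) is accordingly expected to be small. Compound 3 is estimated at 4000 nM, with an expected range of 1300 nM to 12000 nM.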

Compound 3, half-maximal inhibitory concentration: > 25000 nM
Compound 3 gave a limit, no number (the forecaster's own chance of this, stated with the estimate: 10%); middle value at least 6.2-fold (0.79 log units) away from the limit.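

Within the data shown here, this is the first single change that can be read in this assay, and it is not a small one: amino in place of methyl on this aromatic carbon, ortho to a (1H-indazol-6-yl)amino group and para to a large group, gives an at least 6.9-fold higher number from compound 2 to compound 3 (0.84 log units; beyond the scatter). The position is therefore sensitive to what sits on it, even though each group counts only 1 heavy atom; the amino group adds a hydrogen-bond donor and a hydrogen-bond acceptor, but these counts alone do not show what drives the step. The value of compound 3 is a limit and not a number, so the true size of the step stays unknown: the limit of > 25000 nM in this assay, at which 1 of the 3 values shown sits.

On these data alone, with a single pair, it remains open whether this weakening is specific to the amino group or would also follow from other groups on the same carbon, such as hydroxyl, methoxy or a chlorine atom. As far as these compounds go, it also remains open whether the same swap would have a similar effect in a compound that carries a different group elsewhere on the core.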